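Swapping phenyl for 3,4-dimethoxyphenyl: what to expect

The source may hold more compounds than are shown below. What is called first, only, known or untested is meant among the compounds shown, and "the series" means these compounds.

Compound 1 (`COc1ccc(C2=N/C(=C\c3cc(Br)cc(Br)c3OC(C)=O)C(=O)NN2c2ncc(-c3ccccc3)s2)cc1OC`): 4330 nM
Compound 2 (`CC(=O)Oc1c(Br)cc(Br)cc1/C=C1\N=C(c2ccccc2)N(c2ccccc2)NC1=O`): 19400 nM

In a functional assay on MCF7 cells (Homo sapiens) for antiproliferative activity, read by MTT assay, with a stated time of 48 h (a lower number here means a stronger inhibitor, a higher number a weaker inhibitor), compound 2 gives the higher of the two numbers at 19400 nM and so is the weaker inhibitor, with compound 1 lower by a gap beyond the usual scatter. Compound 3 (`COc1ccc(C2=N/C(=C\c3cc(Br)cc(Br)c3OC(C)=O)C(=O)NN2c2ccccc2)cc1OC`) keeps the rest of compound 2 but carries 3,4-dimethoxyphenyl in place of phenyl on a carbon with a double bond to nitrogen. Within the data shown here, no measured pair shows this change alone, so any expectation is loose. Compound 1 at 4330 nM is the only sign of how low the numbers run here. A modest fall in this assay is expected, close to the edge of the scatter, and the estimated step is a 2.2-fold lower number from compound 2 to compound 3 (0.33 log units; beyond the scatter) in size. For compound 3 the estimated value is 9000 nM with an expected range from 3500 nM to 22000 nM in repeated measurements.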

Compound 3, half-maximal inhibitory concentration: 5390 nM
Beside the measured number, compound 3's estimate is 1.7-fold (0.22 log units) above it; measured number inside the range.
By their numbers in this assay, from the lowest: compounds 1 and 3 (each within the scatter of the next); then compound 2.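

In this assay, among these compounds, 3,4-dimethoxyphenyl in place of phenyl on a carbon with a double bond to nitrogen gives a 3.6-fold lower number from compound 2 to compound 3 (0.56 log units; beyond the scatter) as a clean reading of this single change, which the earlier compounds could not provide. With 3,4-dimethoxyphenyl on that carbon, phenyl in place of 5-phenyl-1,3-thiazol-2-yl on an amine nitrogen in a ring gives a 1.2-fold higher number from compound 1 to compound 3 (0.10 log units; within the scatter), so this swap leaves no difference that can be told from scatter. No measurement here explains either step.

On these data alone, it remains open what a single methoxy group, as in 4-methoxyphenyl, or an amine, as in 4-aminophenyl, would give on that carbon. As far as these compounds go, it is also open whether 5-phenyl-1,3-thiazol-2-yl on the ring nitrogen would matter with plain phenyl on the carbon.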